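Cytotoxicity across the benzyl-type substituents on the sulfonamide nitrogen

The source may report more compounds than this note shows. Statements on the series, on what has been measured and on what is new or still open speak of the compounds shown alone.

Measured so far:
compound 1 `O=C1c2sccc2N(Cc2cccc(Cl)c2)S(=O)(=O)N1Cc1ccccc1` — > 298000 nM
compound 2 `O=C1c2sccc2N(Cc2ccc(Cl)cc2)S(=O)(=O)N1Cc1ccccc1` — 8200 nM
compound 3 `O=C1c2sccc2N(Cc2ccc([N+](=O)[O-])cc2)S(=O)(=O)N1Cc1ccccc1` — 268000 nM

In an ADME assay on MT4 cells (Homo sapiens) for cytotoxicity, read by MTT assay, with a stated time of 4 days (on this read-out lower numbers stand for higher toxicity in this test and higher numbers for lower toxicity in this test), compound 1 gives only a limit, > 298000 nM, and sits at the limit of > 298000 nM in this assay, at which 1 of the 3 values shown sits. Compound 2 gives 8200 nM in this assay. Compound 3 gives 268000 nM in this assay and stands highest of the two numbers, with compound 2 nearest at a 33-fold higher number from compound 2 to compound 3 (1.51 log units; beyond the scatter). The other steps at the same position are an at least 36-fold lower number from compound 1 to compound 2 (1.56 log units; beyond the scatter) and an at least 1.1-fold lower number from compound 1 to compound 3 (0.04 log units; that floor lies within the scatter).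

Compound 4 `N#CCN1c2ccsc2C(=O)N(Cc2ccccc2)S1(=O)=O` is not yet measured in this assay. It differs from compound 3 by cyano in place of 4-nitrophenyl on a saturated chain carbon bound to a sulfonamide nitrogen in a ring. All three measured steps bear on it, since each alters the group on the saturated chain carbon bound to the sulfonamide nitrogen in the ring; two of them were large and one lay within the scatter. None of them removes the six-membered aromatic ring, so the direction of the step to compound 4 is uncertain. Compound 4 is expected to stay near compound 3, with the estimated step being a 1.3-fold lower number from compound 3 to compound 4 (0.13 log units; within the scatter), since compound 3 gives 268000 nM. The estimate for compound 4 is 200000 nM, ranging from 30000 nM to 298000 nM.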

Compound 4, half-maximal cytotoxic concentration: 5700 nM
The estimate for compound 4 lay 35-fold (1.55 log units) above the measured number; measured number outside the range, below it.
By their numbers in this assay, from the lowest: compounds 4 and 2 (each within the scatter of the next); then compound 3. At a limit, above all of these: compound 1.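

At the saturated chain carbon bound to a sulfonamide nitrogen in a ring, a group with no ring can still give one of the lowest numbers in the series in this assay: the change to cyano gives a 47-fold lower number from compound 3 to compound 4 (1.67 log units; beyond the scatter), and measured against the limit of compound 1 it gives an at least 52-fold lower number from compound 1 to compound 4 (1.71 log units; beyond the scatter). Against compound 2, the same position gives a 1.4-fold lower number from compound 2 to compound 4 (0.16 log units; within the scatter), so cyano and 4-chlorophenyl cannot be told apart in this test, and the six-membered aromatic ring is not required for a low number, although compound 3 and compound 1 carry that ring and do not show one. Compound 1 gives only a limit, > 298000 nM, and not a number.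

No measured property in this set bears on these steps, and what compound 2 and compound 4 have in common here stays unexplained. An amine, a carboxylic acid or a longer chain ending in a nitrile at this position would show whether the low number follows cyano itself or appears with other small groups that have no ring.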